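Replacing dimethoxyphenyl with pyridin-3-yl in a paw edema test

A few compounds are considered here, and "the series" means these few. Any claim that something is new, unique, unknown or untested is made for them only; others in the source may bear on it.

Of the compounds shown here, three built on one shared core have been tested in a functional assay on the whole organism (strain Wistar) for inhibition, with Rattus norvegicus as the target, read by paw edema, with a stated time of 2 h, at a dose of 10 mg/kg by the intraperitoneal route; on this read-out lower numbers stand for less inhibition and higher numbers for more inhibition at the one dose given (going by the name of the read-out). Compound 1 `O=C(N/N=C/c1ccc(Cl)cc1)c1cccnc1Nc1cccc(C(F)(F)F)c1` gives 52.8%. Compound 2 `COc1ccc(/C=N/NC(=O)c2cccnc2Nc2cccc(C(F)(F)F)c2)c(OC)c1` gives 44.7%, and compound 3 `COc1ccc(/C=N/NC(=O)c2cccnc2Nc2cccc(C(F)(F)F)c2)cc1OC` gives 49%. On the numbers compound 3 lies between the other two, yet every gap among the three is within the usual scatter: a number 3.8 percentage points lower from compound 1 to compound 3 (within the scatter), a number 4.3 percentage points higher from compound 2 to compound 3 (within the scatter), and a number 8.1 percentage points lower from compound 1 to compound 2 (within the scatter).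

Compound 4 `O=C(N/N=C/c1cccnc1)c1cccnc1Nc1cccc(C(F)(F)F)c1` has not yet been measured. It differs from compound 3 in one place: pyridin-3-yl in place of 3,4-dimethoxyphenyl on a carbon with a double bond to nitrogen.

All three measured steps change the group on that same carbon, and none of them moves the read-out beyond the scatter. Exchanging 4-chlorophenyl for 2,4-dimethoxyphenyl or for 3,4-dimethoxyphenyl, and exchanging 2,4-dimethoxyphenyl for 3,4-dimethoxyphenyl, left the inhibition essentially where it was. Since the change to compound 4 again sits on that carbon, and a ring with one nitrogen is a smaller departure than the ones already tried, the expected step is a number 2 percentage points lower from compound 3 to compound 4 (within the scatter), that is, none beyond the scatter. Compound 4 is therefore estimated to give 47% in this assay, with a likely range from 36% to 58%.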

Compound 4, a percentage reported as inhibition, in the whole organism at one dose (the size of the read-out at that dose, not a potency): 62.4%
Compound 4: middle estimate off by 15.4 percentage points, on the low side; the measured number lies above the stated range.
By their numbers in this assay, from the lowest: compounds 2, 3, 1 and 4 (each within the scatter of the next, the first and the last beyond it).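

Within the data shown here, at the carbon with a double bond to nitrogen, the group can change the result in this assay: pyridin-3-yl gives a number 13.4 percentage points higher from compound 3 to compound 4 (beyond the scatter) and a number 17.7 percentage points higher from compound 2 to compound 4 (beyond the scatter) and these are the first steps at this position to pass beyond the scatter. This separation holds only against the two dimethoxyphenyl groups, as the comparison with 4-chlorophenyl gives a number 9.6 percentage points higher from compound 1 to compound 4 (within the scatter) and so does not tell those two groups apart. Nothing measured here explains why the dimethoxyphenyl groups and pyridin-3-yl differ.

The change swaps a carbon-only ring carrying methoxy groups for a ring containing nitrogen, so the compounds shown cannot say whether the ring nitrogen or the absence of the methoxy groups matters more, and plain phenyl would be the natural group to help separate the two. Whether the placement of the nitrogen matters also remains open, as pyridin-4-yl is not among these compounds, and a single dose cannot show how the compounds would compare across a range of doses.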